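A few compounds are considered here, and "the series" means these few. Any claim that something is new, unique, unknown or untested is made for them only; others in the source may bear on it.

Measured compounds:
- Compound 1 `C#CCN(Cc1ccc(OCc2cccc(F)c2)cc1)[C@@H](C)C(N)=O` gives 7790 nM in an assay on Sf9 cells for inhibition of Amine oxidase [flavin-containing] A (Homo sapiens), with stated times of 15 min and 60 min; on this read-out lower numbers stand for stronger inhibition and higher numbers for weaker inhibition.
- Compound 2 `Cc1cc(OCc2cccc(F)c2)ccc1CN[C@@H](C)C(N)=O` reaches only the assay limit in this assay and gives > 10000 nM, a limit rather than a number.
- Compound 3 `C#CCN(Cc1ccc(OCc2cccc(F)c2)cc1F)[C@@H](C)C(N)=O` gives 8710 nM in this assay.

Compound 3 thus holds the highest of the two numbers shown, though its distance from compound 1 is small: a 1.1-fold higher number from compound 1 to compound 3 (0.05 log units; within the scatter). That single step, fluoro in place of hydrogen on an aromatic carbon, is the only one measured here, and it stayed within the scatter. Compound 2 carries a methyl on the shared core but lacks the propargyl group, so it differs from compound 4 in more than one place and its limit of > 10000 nM in this assay, at which 1 of the 3 values shown sits, cannot be read as a step.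

Compound 4 `C#CCN(Cc1ccc(OCc2cccc(F)c2)cc1C)[C@@H](C)C(N)=O` differs from compound 3 by methyl in place of fluoro on an aromatic carbon. Going by the values given here, the one comparable change, from compound 1 to compound 3 at this ring, moved the number hardly at all, so the expected step in this assay from compound 3 to compound 4 is none beyond the scatter: a 1.0-fold higher number from compound 3 to compound 4 (0.01 log units; within the scatter). The estimate for compound 4 in this assay is therefore 9000 nM, with a range from 4000 nM to 20000 nM.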

Compound 4, half-maximal inhibitory concentration: 6400 nM
Compound 4: the middle estimate sits 1.4-fold (0.15 log units) above what was measured; the range from low to high includes it.
By their numbers in this assay, from the lowest: compounds 4, 1 and 3 (each within the scatter of the next). At a limit, above all of these: compound 2.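

At this ring carbon, ortho to a large group, a third substituent now joins hydrogen and fluoro, and methyl does not separate from either of them in this assay: the change from fluoro gives a 1.4-fold lower number from compound 3 to compound 4 (0.13 log units; within the scatter), and the change from hydrogen gives a 1.2-fold lower number from compound 1 to compound 4 (0.09 log units; within the scatter). Compound 1 and compound 3 alone showed only that a fluoro made no readable difference, whereas these steps show the same for a methyl, a group built on a different element, so the three compounds with a propargyl group on the amine nitrogen cannot be told apart here. Compound 2, which has a hydrogen in place of that propargyl, gives a limit and not a number: the limit of > 10000 nM in this assay, at which 1 of the 4 values shown sits. For that reason, the effect of the propargyl group on the amine nitrogen can be sized only as a floor, and it is a small one: an at least 1.5-fold lower number from compound 2 to compound 4 (0.19 log units; that floor lies within the scatter).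

As far as these compounds go, it remains open whether a methoxy group, a chlorine or an amine at this ring carbon would move the number beyond the scatter. Also open, from the compounds shown here alone, is how far the propargyl group itself matters, and whether a longer chain on the same nitrogen, such as butynyl, would change the result.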